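The source may hold more compounds than are shown below. What is called first, only, known or untested is meant among the compounds shown, and "the series" means these compounds.

Three compounds share one core and differ only in a single chain: compound 1 `CCN(C1=NCCN1)c1c(Br)cccc1Br`, compound 2 `CC(C)CCN(C1=NCCN1)c1c(Br)cccc1Br` and compound 3 `C/C=C/CN(C1=NCCN1)c1c(Br)cccc1Br`. In a physicochemical assay for acid dissociation, compound 1 gives 11.1, compound 2 gives 10.9 and compound 3 gives 11. Compound 3 cannot be separated from either of the others, since the measurements show a number 0.10 log units lower from compound 1 to compound 3 (within the scatter) and a number 0.10 log units higher from compound 2 to compound 3 (within the scatter). The remaining pair behaves the same way, with a number 0.20 log units lower from compound 1 to compound 2 (within the scatter).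

Compound 4 `C=CCCN(C1=NCCN1)c1c(Br)cccc1Br` has not yet been measured. It has the same atoms as compound 3, joined differently: allyl in place of prop-1-en-1-yl on a saturated chain carbon bound to a nitrogen on an aromatic ring. For the measured compounds named here, no measured step makes exactly this swap. The closest guides are the two changes at that same place, a number 0.10 log units lower from compound 1 to compound 3 (within the scatter) and a number 0.10 log units higher from compound 2 to compound 3 (within the scatter), and neither rises above the noise of the method. The step of a number 0.20 log units lower from compound 1 to compound 2 (within the scatter), made further along the chain, stays within the scatter as well. A shift beyond the scatter is therefore not expected, and the estimated step is no change at the digits printed from compound 3 to compound 4 (within the scatter). Compound 4 is expected at 11, with an estimated range from 10.7 to 11.3.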

Compound 4, acid dissociation constant: 11.2
Compound 4: the middle estimate sits 0.20 log units below what was measured; the measured number falls inside the stated range.
By their numbers in this assay, from the lowest: compounds 2, 3, 1 and 4 (each within the scatter of the next).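

In this assay, for the compounds shown here, moving the double bond along a chain of unchanged atoms, with allyl in place of prop-1-en-1-yl on a saturated chain carbon bound to a nitrogen on an aromatic ring, gives a number 0.20 log units higher from compound 3 to compound 4 (within the scatter) and so offers the first direct look at a change in connectivity alone at this position. Set against the saturated chains, on a saturated chain carbon two bonds along the chain from a nitrogen on an aromatic ring, vinyl in place of isopropyl gives a number 0.30 log units higher from compound 2 to compound 4 (within the scatter) and vinyl in place of hydrogen gives a number 0.10 log units higher from compound 1 to compound 4 (within the scatter) in this same reading. All four compounds therefore stay within the scatter of one another, so neither the position of the double bond nor its presence separates these chains in this assay.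

Every chain shown is built from carbon and hydrogen alone, so what an amine, a carboxylic acid or a much longer chain at this place would do to the number remains open. Nothing else is available here that could explain why these four numbers lie so close together.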